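A Halogen Swap on the Ether Ring and Clearance

This account rests on a few compounds, and the source may have more. Where it says the series, first, only, none or still open, it means among the compounds named here.

Of the compounds shown here, two have been measured in an ADME assay on microsomes from liver (Homo sapiens) for metabolic stability, read by HPLC, using NADPH, with stated times of 5 min and 60 min, tested at 10 uM; on this read-out lower numbers stand for slow clearance and higher numbers for fast clearance. Compound 1 `CCS(=O)(=O)Nc1ccc(Oc2ccc(C#N)cc2)c(-c2cn(C)c(=O)c3[nH]ccc23)c1` gives 41.7 mL/min/kg in this assay. Compound 2 `Cn1cc(-c2cc(NS(C)(=O)=O)ccc2Oc2ccccc2C(F)(F)F)c2cc[nH]c2c1=O` gives 533 mL/min/kg in this assay, the highest of the two numbers, and its gap to compound 1 lies beyond the scatter. These two structures differ in more than one place, so no single change can be read out of that gap. Compound 3 `Cn1cc(-c2cc(NS(C)(=O)=O)ccc2Oc2ccc(F)cc2Cl)c2cc[nH]c2c1=O` has not yet been measured. It differs from compound 2 in one place: 2-chloro-4-fluorophenyl in place of 2-(trifluoromethyl)phenyl on an oxygen on an aromatic ring. Among the compounds with values here, no measured pair shows this change, so the data give no direct anchor for it. For compound 3 the step of a 1.5-fold lower number from compound 2 to compound 3 (0.18 log units; within the scatter) is expected to be modest and downward, quite possibly within the scatter. Compound 3 is therefore estimated at 350 mL/min/kg, with a range from 130 mL/min/kg to 900 mL/min/kg.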

Compound 3, clearance: 233 mL/min/kg
Compound 3: middle estimate off by 1.5-fold (0.18 log units), on the high side; the measured number falls inside the stated range.
By their numbers in this assay, from the lowest: compound 1; then compound 3; then compound 2.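

Within the data shown here, compound 2 and compound 3 give the first comparison here that differs in only one place, and it shows that the group on an oxygen on an aromatic ring can shift clearance by itself. In this assay, putting 2-chloro-4-fluorophenyl in place of 2-(trifluoromethyl)phenyl gives a 2.3-fold lower number from compound 2 to compound 3 (0.36 log units; beyond the scatter), a modest step that still lies beyond the usual scatter. No measurement shown here explains why the number falls.

From the compounds shown here alone, the swap removes the trifluoromethyl group and adds a chlorine and a fluorine together, so the contribution of each halogen stays open. Also open, going by these compounds, is how clearance would respond if this oxygen carried a phenyl ring bearing a methoxy group or an amine.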